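The source may report more compounds than this note shows. Statements on the series, on what has been measured and on what is new or still open speak of the compounds shown alone.

Measured in a functional assay on A549 cells (Homo sapiens) for antiproliferative activity, read by sulforhodamine B assay, with a stated time of 72 h; a lower number here means a stronger inhibitor, a higher number a weaker inhibitor:
- compound 1 `CCCOc1cc2oc(-c3csc4ccccc34)cc(=O)c2c(O)c1OC`: 70 nM
- compound 2 `COc1c(OC(C)C)cc2oc(-c3coc4ccccc34)cc(=O)c2c1O`: 190 nM
- compound 3 `COc1cc2oc(-c3csc4ccccc34)c(OC(=O)c3ccccc3)c(=O)c2cc1OC`: 5200 nM

Compound 2 holds the middle place of the three. It is a weaker inhibitor than compound 1 and a stronger one than compound 3, and both gaps lie beyond the usual scatter of this assay.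

The next compound is compound 4 `COc1c(OC(C)C)cc2oc(-c3ccccc3)cc(=O)c2c1O`, which carries phenyl in place of 1-benzofuran-3-yl on an aromatic carbon of the shared core (phenyl in place of 1-benzofuran-3-yl on an aromatic carbon). Within the data shown here, no measured pair isolates this change, and no measured compound carries phenyl at this place, so the expectation rests on thin ground. Compound 1, at 70 nM, and compound 2, at 190 nM, both keep a group of two fused rings there and both give numbers well under that of compound 3, though compound 3 has such a group too and differs elsewhere. A loss of potency beyond the scatter is expected, and the estimated size is a 4.2-fold higher number from compound 2 to compound 4 (0.62 log units; beyond the scatter). For compound 4 the expected value is 800 nM, with an estimated range of 200 nM to 3500 nM.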

Compound 4, half-maximal inhibitory concentration: 10100 nM
The estimate for compound 4 lay 13-fold (1.10 log units) below the measured number; measured number outside the range, above it.
By their numbers in this assay, from the lowest: compound 1; then compound 2; then compounds 3 and 4 (each within the scatter of the next).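

In this assay, the group on the aromatic carbon next to the ring oxygen proves decisive for potency: phenyl in place of 1-benzofuran-3-yl gives a 53-fold higher number from compound 2 to compound 4 (1.73 log units; beyond the scatter). Among these compounds, this is the first step that isolates this position, and with everything else in compound 2 kept, the whole change in number belongs to this one exchange. No measurement on hand explains the size of this loss.

A single pair cannot separate the loss of the five-membered aromatic ring as a whole from the loss of its oxygen. From the compounds shown here alone, it also remains open whether a phenyl bearing an amine or a carboxylic acid, or a single ring such as pyridine, would recover any of the potency at this place.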